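Ester homologation on the shared core: compound 3

A few compounds are considered here, and "the series" means these few. Any claim that something is new, unique, unknown or untested is made for them only; others in the source may bear on it.

Measured so far:
compound 1 `COC(=O)c1ccc2ccc(C(=O)c3ccccc3)c-2cc1` — 7.2%
compound 2 `COC(=O)c1ccc2ccc(C=O)c-2cc1` — 25%

In an assay on cells for displacement of a labelled ligand from Orexin/Hypocretin receptor type 1 (Homo sapiens), read by scintillation counting, with stated times of 10 min and 90 min, tested at 10 uM (a higher number here means more inhibition at the concentration tested (going by the name of the read-out), a lower number less inhibition), compound 1 stands lowest of the two numbers; compound 2 is the nearest, and the step of a number 17.8 percentage points higher from compound 1 to compound 2 (beyond the scatter) lies beyond the scatter. Compound 3 `COC(=O)Cc1ccc2ccc(C(=O)c3ccccc3)c-2cc1` differs from compound 1 by (methoxycarbonyl)methyl in place of methoxycarbonyl on an aromatic carbon. Within the data shown here, no measured step bears on this change: the only step known, a number 17.8 percentage points higher from compound 1 to compound 2 (beyond the scatter), alters a different place. No step beyond the scatter is therefore expected for compound 3, an expected change of a number 2.8 percentage points higher from compound 1 to compound 3 (within the scatter). The estimate for compound 3 is 10%, with an expected range from 0% to 25%.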

Compound 3, a percentage reported as inhibition, at one concentration (the size of the read-out at that concentration, not a potency): -37.7%
For compound 3 the middle estimate is 47.7 percentage points above the measured one, and the stated range ends above it.
By their numbers in this assay, from the lowest: compound 3; then compound 1; then compound 2.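

In this assay, the position on an aromatic carbon of the seven-membered aromatic ring responds strongly to a small change: (methoxycarbonyl)methyl in place of methoxycarbonyl gives a number 44.9 percentage points lower from compound 1 to compound 3 (beyond the scatter). Among these compounds, compound 3 at -37.7% is also the first negative number in this inhibition read-out. Nothing available explains this step.

Open, going by these compounds, is how a carboxylic acid, an amine or a longer ester chain would read at this position. Also open, on these data alone, is whether the step carries over to the aldehyde core of compound 2.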